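A few compounds are considered here, and "the series" means these few. Any claim that something is new, unique, unknown or untested is made for them only; others in the source may bear on it.

Measured compounds in the series:
- compound 1, `Cc1cnc(-c2ccccc2C(C)C)nc1NCc1ccc(-c2ccnc(C(F)(F)F)c2)cc1`: 320 nM
- compound 2, `Cc1cnc(-c2ccccc2C(C)C)nc1NCc1ccc(-c2nnn[nH]2)cc1`: 5900 nM

Both were read in an assay on a protein complex for inhibition of ubiquitin carboxyl-terminal hydrolase 1/WD repeat-containing protein 48 (Homo sapiens), read by fluorescence; on this read-out higher numbers stand for weaker inhibition and lower numbers for stronger inhibition. Compound 2 stands at the highest number of the two; its nearest neighbour is compound 1, and the step of an 18-fold higher number from compound 1 to compound 2 (1.27 log units; beyond the scatter) lies beyond the scatter. That single step is the only one bearing on the next change: it shows how far the number moved when the 2-(trifluoromethyl)pyridin-4-yl group gave way to the 1H-tetrazol-5-yl group on the same aromatic carbon.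

Compound 3, `Cc1cnc(-c2ccccc2C(C)C)nc1NCc1ccc(-n2ccnc2)cc1`, has not yet been measured. Its difference from compound 2 is 1H-imidazol-1-yl in place of 1H-tetrazol-5-yl on an aromatic carbon. The change keeps a five-membered aromatic ring at the same place but swaps the hetero-atom count and removes the hydrogen-bond donor. Since the tetrazole analogue gave the weakest result, and the step from compound 1 to compound 2 was large, a partial reversal is expected rather than a full return to the value of compound 1. The estimated step is a 3.9-fold lower number from compound 2 to compound 3 (0.59 log units; beyond the scatter). Compound 3 is therefore expected at 1500 nM, with a range from 450 nM to 5000 nM.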

Compound 3, half-maximal inhibitory concentration: 300 nM
Beside the measured number, compound 3's estimate is 5.0-fold (0.70 log units) above it; the measured number lies below the stated range.
By their numbers in this assay, from the lowest: compounds 3 and 1 (each within the scatter of the next); then compound 2.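

In this assay, putting 1H-imidazol-1-yl in place of 1H-tetrazol-5-yl gives a 20-fold lower number from compound 2 to compound 3 (1.29 log units; beyond the scatter) and shows that a five-membered aromatic ring on this aromatic carbon, para to a large group, does not in itself bring the high number of compound 2. The other new step is a 1.1-fold lower number from compound 1 to compound 3 (0.03 log units; within the scatter) and lies within the scatter, so a 2-(trifluoromethyl)pyridin-4-yl group is not required at this place to reach this level, and among the three groups only 1H-tetrazol-5-yl stands apart. The change from compound 2 to compound 3 alters the hetero-atom count and removes the hydrogen-bond donor together, and no measurement shown here separates these two differences or explains the step.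

Going by these compounds, it remains open whether the number follows the hetero-atom count or the donor, which 1H-pyrazol-1-yl and 1H-1,2,3-triazol-1-yl at this place could help to separate. A carboxylic acid or a simple amine on the same carbon would test whether the high number is particular to 1H-tetrazol-5-yl or extends to other kinds of group.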